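Chromone ethers: benzoxazolylmethoxy in place of methylbenzyloxy

A few compounds are considered here, and "the series" means these few. Any claim that something is new, unique, unknown or untested is made for them only; others in the source may bear on it.

Measured so far:
compound 1 `COc1ccc(-c2cc(=O)c3c(O)cc(OCCCCN4CCN(C)CC4)c(OC)c3o2)cc1`: in a functional assay on HepG2 cells (Homo sapiens) for cytotoxicity, read by MTT assay, with a stated time of 72 h (on this read-out lower numbers stand for stronger inhibition and higher numbers for weaker inhibition), compound 1 gives 4200 nM
compound 2 `Cc1ccc(COc2cc(O)c3c(=O)cc(-c4ccccc4)oc3c2OCCCCN2CCN(C)CC2)cc1`: in this assay compound 2 gives 5090 nM

Compound 2 and compound 1 sit within the usual scatter of each other in this assay, so the two numbers cannot be told apart on what has been measured. Among the measured compounds shown here, no step between compounds differing in one place is available for this series.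

Compound 3 `CN1CCN(CCCCOc2c(OCc3nc4ccccc4o3)cc(O)c3c(=O)cc(-c4ccccc4)oc23)CC1` is the next compound, not yet measured. It differs from compound 2 in one place: 1,3-benzoxazol-2-yl in place of 4-methylphenyl on a saturated chain carbon bound to an oxygen on an aromatic ring. The shared core and the chain bearing the methylpiperazine are unchanged.

For the measured compounds named here, with no comparable step measured, the expectation is for a step no larger than the scatter, in either direction, from compound 2 to compound 3. On that basis compound 3 is estimated at 5000 nM in this assay, with a range of 1800 nM to 14000 nM; the step of a 1.0-fold lower number from compound 2 to compound 3 (0.01 log units; within the scatter) is therefore expected to be small.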

Compound 3, half-maximal inhibitory concentration: 4110 nM
Compound 3: the middle estimate sits 1.2-fold (0.09 log units) above what was measured, and the stated range covers the measured number.
By their numbers in this assay, from the lowest: compounds 3, 1 and 2 (each within the scatter of the next).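

On a saturated chain carbon bound to an oxygen on an aromatic ring, 1,3-benzoxazol-2-yl in place of 4-methylphenyl gives, in this assay, a 1.2-fold lower number from compound 2 to compound 3 (0.09 log units; within the scatter). Among the compounds shown here, this is the only single-place step so far, and it shows that this position can take a five-membered aromatic ring with 2 hetero atoms and 2 hydrogen-bond acceptors, in addition to the six-membered ring, with no difference that can be told from the scatter. Nothing measured here speaks to why the two numbers stay together.

One pair at one position cannot show whether the number would hold with a primary amine or a carboxylic acid on that chain carbon. Going by these compounds, the effect of a longer chain carrying the methylpiperazine also remains open.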